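Aryl Swap on the Triazole of a Weakly Antiproliferative Series

This account rests on a few compounds, and the source may have more. Where it says the series, first, only, none or still open, it means among the compounds named here.

Compound 2 `Cc1ccc(C)c(-n2nncc2CN2C(=O)C3(C(C#N)=C(N)Oc4c(N)cc5nc6ccccc6nc5c43)c3ccccc32)c1` is one of two close relatives tested in a functional assay on MCF7 cells (Homo sapiens) for antiproliferative activity, read by MTT assay, with a stated time of 48 h; on this read-out higher numbers stand for weaker inhibition and lower numbers for stronger inhibition. In this assay compound 2 reaches only the limit > 50000 nM, so its position is a floor rather than a number. Its neighbour compound 1 `N#CC1=C(N)Oc2c(N)cc3nc4ccccc4nc3c2C12C(=O)N(Cc1cnnn1-c1ccccc1Br)c1ccccc12` gives 30700 nM in this assay. Going by the values given here, the one measured step, an at least 1.6-fold higher number from compound 1 to compound 2 (0.21 log units; that floor lies within the scatter), therefore cannot be separated from the scatter, and it is bounded by the limit of > 50000 nM in this assay, at which 1 of the 2 values shown sits. Compound 3 `Cc1ccc(-n2nncc2CN2C(=O)C3(C(C#N)=C(N)Oc4c(N)cc5nc6ccccc6nc5c43)c3ccccc32)cc1Cl` carries 3-chloro-4-methylphenyl in place of 2,5-dimethylphenyl on an aromatic nitrogen. Among the compounds with values here, this change again exchanges one substituted phenyl for another on the same aromatic nitrogen, and the only comparable step was flat, so no movement beyond the scatter is expected in this assay. Compound 3 is therefore estimated at 45000 nM, between 18000 nM and 110000 nM, which corresponds to an expected step of an at least 1.1-fold lower number from compound 2 to compound 3 (0.04 log units; that floor lies within the scatter) that may well again end at the limit.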

Compound 3, half-maximal inhibitory concentration: > 50000 nM
Compound 3 was reported as a limit; the forecaster's own chance of this, stated with the estimate: 55%; middle value at least 1.1-fold (0.04 log units) away from the limit.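

Compound 3 shows that a second aryl group on this aromatic nitrogen, 3-chloro-4-methylphenyl, which brings in a chlorine, also ends at a limit in this assay, so the limit is not peculiar to the 2,5-dimethylphenyl of compound 2. Measured against the 2-bromophenyl of compound 1, the change gives an at least 1.6-fold higher number from compound 1 to compound 3 (0.21 log units; that floor lies within the scatter), so this swap, like the earlier one, cannot be separated from the scatter, and the step between compound 2 and compound 3 cannot be read at all. What this position can reveal in this series is capped: the limit of > 50000 nM in this assay, at which 2 of the 3 values shown sit.

On these data alone, whether any group on this nitrogen moves the value beyond the scatter remains open. A phenyl bearing an amine or a carboxylic acid, or a longer chain in place of the aryl group, is not among the compounds shown.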